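The source may hold more compounds than are shown below. What is called first, only, known or untested is meant among the compounds shown, and "the series" means these compounds.

Compound 2, `CC(=O)SCC(=O)c1ccc(NS(=O)(=O)c2ccc(OCCCc3ccccn3)cc2)nc1`, has no result in a functional assay on HCT-116 cells (Homo sapiens) for cytotoxicity; on this read-out higher numbers stand for an effect only at larger amounts of compound and lower numbers for an effect already at smaller amounts: its value in this assay is "not determined" (no result reported). Two related compounds give a sense of the range. Compound 1, `CC(=O)SCC(=O)c1ccc(NS(=O)(=O)c2ccc3c(c2)COOC3)nc1`, gives 1200 nM in this assay, and compound 3, `COc1cccc(S(=O)(=O)Nc2ccc(C(=O)CSC(C)=O)cn2)c1`, gives 4300 nM. Compound 4, `CC(=O)SCC(=O)c1ccc(NS(=O)(=O)c2ccc(OCCc3ccccn3)cc2)nc1`, differs from compound 2 in one place: pyridin-2-yl in place of (pyridin-2-yl)methyl on a saturated chain carbon, two bonds along the chain from an oxygen on an aromatic ring. Within the data shown here, since compound 2 has no number, no measured step can anchor the move to compound 4; with only the chain shortened and the same aromatic ring retained, the author expects a step in this assay that, if present at all, stays within the usual scatter, in no clear direction. On this basis compound 4 is estimated at 2500 nM, with a range from 700 nM to 9000 nM.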

Compound 4, half-maximal effective concentration: 750 nM
Compound 4: the middle estimate sits 3.3-fold (0.52 log units) above what was measured; low and high end bracket the measured number.
By their numbers in this assay, from the lowest: compounds 4 and 1 (each within the scatter of the next); then compound 3.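

No step can be read from compound 2 to compound 4 in this assay, and no evidence bears on this result. The compounds shown leave open whether 3-(pyridin-2-yl)propoxy and 2-(pyridin-2-yl)ethoxy differ in this assay at all.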